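The source may hold more compounds than are shown below. What is called first, only, known or untested is meant among the compounds shown, and "the series" means these compounds.

Measured compounds:
Compound 1, `O=C(Nc1cccc(-n2cc(-c3ccncc3)c(-c3ccc(Cl)c(O)c3)n2)c1)Nc1cccc(C(F)(F)F)c1`: in a functional assay on A498 cells (Homo sapiens) for inhibition, read by sulforhodamine B assay, with a stated time of 48 h (on this read-out higher numbers stand for weaker inhibition of growth and lower numbers for stronger inhibition of growth), compound 1 gives > 32500 nM, a limit of the assay rather than a number.
Compound 2, `COc1cc(-c2nn(-c3cccc(NC(=O)Nc4cc(C(F)(F)F)cc(C(F)(F)F)c4)c3)cc2-c2ccncc2)ccc1Cl`: in this assay compound 2 gives 1900 nM.

Within the data shown here, compound 2 therefore carries the only true number in this assay; the other entry is a limit (the limit of > 32500 nM in this assay, at which 1 of the 2 values shown sits). Compound 3, `O=C(Nc1cccc(-n2cc(-c3ccncc3)c(-c3ccc(Cl)c(O)c3)n2)c1)Nc1cc(C(F)(F)F)cc(C(F)(F)F)c1`, is built from compound 2 by one change: hydrogen in place of methyl on an oxygen on an aromatic ring. Among the measured compounds shown here, no measured pair differs in exactly this one place, so the size of the step cannot be read off a measured comparison. Compound 1 also carries the hydroxy group and sits at the limit, but it differs from compound 2 in two places, so its value alone cannot be assigned to the hydroxy change. For the measured compounds named here, still, the only hydroxy compound measured shows no growth inhibition within the tested range, so a weakening beyond the scatter is expected for the step of a 4.2-fold higher number from compound 2 to compound 3 (0.62 log units; beyond the scatter). Compound 3 is accordingly estimated at 8000 nM, within a range from 2500 nM to 32500 nM.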

Compound 3, concentration for total growth inhibition: 4330 nM
The estimate for compound 3 lay 1.8-fold (0.27 log units) above the measured number, within the range that was stated.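

In this assay, going from the 4-chloro-3-methoxyphenyl group to the 4-chloro-3-hydroxyphenyl group gives a 2.3-fold higher number from compound 2 to compound 3 (0.36 log units; beyond the scatter), so the hydroxy group weakens growth inhibition only modestly and does not abolish it. Among these compounds, the earlier compounds could not show this, since the only hydroxy compound then known sat at a limit, and compound 3 now shows that a second trifluoromethyl group makes a clear difference when the hydroxy group is present: an at least 7.5-fold lower number from compound 1 to compound 3 (0.87 log units; beyond the scatter). This step has no exact size because compound 1 gives a limit, not a number: the limit of > 32500 nM in this assay, at which 1 of the 3 values shown sits.

The compounds shown leave open how an amine or an ethoxy group would behave on this aromatic carbon in place of hydroxy or methoxy. They also leave open whether the second trifluoromethyl group makes a similar difference when methoxy is present.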